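This account rests on a few compounds, and the source may have more. Where it says the series, first, only, none or still open, it means among the compounds named here.

Of the compounds shown here, three built on one shared core have been read in an ADME assay on Caco-2 cells (Homo sapiens) for permeability, read by LC-MS, in the apical to basolateral direction, with a stated time of 60 min, at pH 6.5; on this read-out lower numbers stand for lower permeability and higher numbers for higher permeability. Within the data shown here, compound 1 `CC(C)(C)[C@@H](O)C(=O)N1[C@@H]2C[C@@H]2C[C@H]1C(=O)NCc1cc(Cl)ccc1-n1cnnn1` gives 34 10^-6 cm/s, the highest of the three numbers so far, though not set apart from all of them. Compound 2 `CC(C)(C)[C@@H](O)C(=O)N1CSC[C@H]1C(=O)NCc1cc(Cl)ccc1-n1cnnn1` gives 19 10^-6 cm/s, a number that sits within the scatter of compound 1. Compound 3 `CCCC[C@@H](O)C(=O)N1N=CC[C@H]1C(=O)NCc1cc(Cl)ccc1-n1cnnn1` gives 9.8 10^-6 cm/s, which lies beyond the scatter below compound 1. Compound 4 `CC(C)(C)C[C@@H](O)C(=O)N1[C@@H]2C[C@@H]2C[C@H]1C(=O)NCc1cc(Cl)ccc1-n1cnnn1` differs from compound 1 by one change: neopentyl in place of tert-butyl on a saturated chain carbon bound to a carbonyl carbon and an oxygen on a saturated carbon. Among the measured compounds shown here, no measured pair shows this change, so the expected step from compound 1 to compound 4 in this assay is small, estimated as a 1.1-fold higher number from compound 1 to compound 4 (0.05 log units; within the scatter), within the scatter and, if anything, toward a higher number. Compound 4 is therefore estimated at 38 10^-6 cm/s, in a range from 20 10^-6 cm/s to 70 10^-6 cm/s.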

Compound 4, apparent permeability: 24 10^-6 cm/s
Beside the measured number, compound 4's estimate is 1.6-fold (0.20 log units) above it, and the stated range covers the measured number.
By their numbers in this assay, from the lowest: compounds 3, 2, 4 and 1 (each within the scatter of the next, the first and the last beyond it).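

Neopentyl in place of tert-butyl, on a saturated chain carbon bound to a carbonyl carbon and an oxygen on a saturated carbon, gives a 1.4-fold lower number from compound 1 to compound 4 (0.15 log units; within the scatter) and so provides the first pair in the series that differs in one place. At this position, the added carbon leaves the read-out within the scatter. Nothing available accounts for the size of this step. As far as these compounds go, whether a longer chain, or a chain bearing an amine or a carboxylic acid, would also stay within the scatter remains open. So does whether the same change would behave alike on the core of compound 2.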